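The compounds below may be only part of what the source reports. "The series", "measured", "known", "first", "only" and "open" are said of these compounds alone.

Compound 1 `Cc1ccc(-c2nc(CNc3ccc(C(=O)NO)cc3)n(-c3ccccc3)n2)cc1` gives 62.2% in an assay on Sf9 cells for inhibition of protein deacetylase HDAC6 (Homo sapiens), read by fluorescence, with a stated time of 40 min, tested at 100 nM; on this read-out lower numbers stand for less inhibition and higher numbers for more inhibition at the one concentration tested (going by the name of the read-out). Compound 2 `COc1ccc(-c2nc(CNc3ccc(C(=O)NO)cc3)n(-c3ccccc3)n2)cc1` gives 77.6%. Compound 3 `Cc1ccccc1-c1nc(CNc2ccc(C(=O)NO)cc2)n(-c2ccccc2)n1` gives 53.2%.

Compound 3 stands lowest of the three numbers in this assay: the step of a number 9 percentage points lower from compound 1 to compound 3 (within the scatter) is within the scatter, whereas a number 24.4 percentage points lower from compound 2 to compound 3 (beyond the scatter) lies beyond it. Compound 4 `Cc1ccsc1-c1nc(CNc2ccc(C(=O)NO)cc2)n(-c2ccccc2)n1` differs from compound 3 by 3-methylthiophen-2-yl in place of 2-methylphenyl on an aromatic carbon. Among the measured compounds shown here, no measured step exchanges the six-membered ring for a five-membered one; the steps seen, a number 15.4 percentage points higher from compound 1 to compound 2 (beyond the scatter) and a number 24.4 percentage points lower from compound 2 to compound 3 (beyond the scatter), concern only what sits on that ring and are modest. The step to compound 4 is therefore expected to stay within the scatter, a number 1.8 percentage points higher from compound 3 to compound 4 (within the scatter). Compound 4 is estimated at 55%, between 35% and 75%.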

Compound 4, a percentage reported as inhibition, at one concentration (the size of the read-out at that concentration, not a potency): 72.1%
The estimate for compound 4 lay 17.1 percentage points below the measured number, and the stated range covers the measured number.
By their numbers in this assay, from the lowest: compounds 3, 1, 4 and 2 (each within the scatter of the next, the first and the last beyond it).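

In this assay the change of ring at this aromatic carbon is a visible one: the step is a number 18.9 percentage points higher from compound 3 to compound 4 (beyond the scatter) and shows that a methyl-bearing ring here need not stay at the number of compound 3. The same group sits level with 4-methoxyphenyl and 4-methylphenyl, with a number 5.5 percentage points lower from compound 2 to compound 4 (within the scatter) and a number 9.9 percentage points higher from compound 1 to compound 4 (within the scatter) as the steps. Nothing measured here accounts for the gain over 2-methylphenyl. Still open, on these data alone, is whether the sulfur, the ring size or the methyl carries this step, and how a furan or pyridine ring would compare. An amine or carboxylic acid on this ring also remains untested in the compounds shown.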